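A few compounds are considered here, and "the series" means these few. Any claim that something is new, unique, unknown or untested is made for them only; others in the source may bear on it.

Three compounds have numbers in an ADME assay for permeability; a higher number here means that the compound crosses the layer faster, a lower number that the compound crosses the layer more slowly. Compound 1 `CNC(=O)c1cc(C(=O)N[C@H]2CC[C@H](O)CC2)n([C@@H](C)c2ccc(Cl)cc2)n1` gives 180 nm/s, compound 2 `CCCNC(=O)c1cc(C(=O)NC)nn1[C@@H](C)c1ccccc1` gives 560 nm/s, and compound 3 `CNC(=O)c1cc(C(=O)NCCO)n([C@@H](C)c2ccccc2)n1` gives 59 nm/s, the lowest of the three. Compound 4 `CNC(=O)c1cc(C(=O)N[C@H]2CC[C@H](O)CC2)n([C@@H](C)c2ccccc2)n1` keeps the core of compound 3 but carries 4-hydroxycyclohexyl in place of 2-hydroxyethyl on an amide-type nitrogen. Going by the values given here, the only measured step is a 9.5-fold lower number from compound 2 to compound 3 (0.98 log units; beyond the scatter), with hydroxy in place of methyl on a saturated chain carbon. That step bears on the change only indirectly, since the hydroxy group stays in both compound 3 and compound 4. The closer guide is compound 1, which has the same 4-hydroxycyclohexyl group together with a chlorine that compound 4 lacks. Compound 1 stands at 180 nm/s. Among the compounds with values here, no measured step isolates that chlorine, so this guide is loose. A moderate rise is therefore expected in this assay, with an estimated 2.2-fold higher number from compound 3 to compound 4 (0.34 log units; beyond the scatter). Compound 4 is expected at 130 nm/s, within an estimated range of 65 nm/s to 260 nm/s.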

Compound 4, apparent permeability: 80 nm/s
For compound 4 the middle estimate is 1.6-fold (0.21 log units) above the measured one, and the stated range covers the measured number.
By their numbers in this assay, from the lowest: compounds 3 and 4 (each within the scatter of the next); then compound 1; then compound 2.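

In this assay, 4-hydroxycyclohexyl in place of 2-hydroxyethyl on the amide-type nitrogen gives a 1.4-fold higher number from compound 3 to compound 4 (0.13 log units; within the scatter), so the two hydroxy-bearing groups cannot be told apart at this position, even though the entering group brings a six-membered ring and more heavy atoms. Set against propyl at the same place, the 4-hydroxycyclohexyl group gives a 7.0-fold lower number from compound 2 to compound 4 (0.85 log units; beyond the scatter), a step of the same order as a 9.5-fold lower number from compound 2 to compound 3 (0.98 log units; beyond the scatter). Going by these compounds alone, compound 4 also isolates the chlorine on the aromatic ring for the first time, and hydrogen in its place gives a 2.3-fold lower number from compound 1 to compound 4 (0.35 log units; beyond the scatter).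

From the compounds shown here alone, it remains open whether plain cyclohexyl, or a cyclohexyl ring carrying an amine instead of the hydroxy, would stand nearer compound 2 or compound 4. No evidence is available to explain any of these differences.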